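The source may hold more compounds than are shown below. What is called first, only, known or untested is meant among the compounds shown, and "the series" means these compounds.

Compound 1 `CCNC(=O)c1cc(Oc2ccc(NC(=O)c3cc4cccnc4n(-c4ccccc4F)c3=O)cc2)ccn1` and compound 2 `CCNC(=O)c1cc(Oc2ccc(NC(=O)c3cc4cccnc4n(-c4ccc(OC)cc4)c3=O)cc2)ccn1` share a core and differ only in the group on the aromatic nitrogen. In a functional assay on NCI-H460 cells (Homo sapiens) for antiproliferative activity, read by MTT assay, with a stated time of 72 h (a lower number here means a stronger inhibitor, a higher number a weaker inhibitor), compound 1 gives 1230 nM, and compound 2 gives 1720 nM; the step of a 1.4-fold higher number from compound 1 to compound 2 (0.15 log units; within the scatter) shows that exchanging one aryl group for another on that nitrogen left the result essentially unchanged. Compound 3 `CCNC(=O)c1cc(Oc2ccc(NC(=O)c3cc4cccnc4n(-c4ccc(F)c(Cl)c4)c3=O)cc2)ccn1` carries a third aryl group on the same nitrogen, but in this assay compound 3 gives "not determined" (no result reported), so compound 3 stands without a number of its own; the two neighbours compound 1 and compound 2 are the only anchors available.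

Compound 4 `CCCNC(=O)c1cc(Oc2ccc(NC(=O)c3cc4cccnc4n(-c4ccc(F)c(Cl)c4)c3=O)cc2)ccn1` differs from compound 3 by methyl in place of hydrogen on a saturated chain carbon, two bonds along the chain from an amide-type nitrogen, that is, ethyl to propyl on the amide at the other end of the molecule. Among the compounds with values here, no measured step touches this part of the structure, so the only guide is that the sole measured step, from one aryl group to another, stayed within the scatter. On that basis compound 4 is expected to land near the values of compound 1 and compound 2, with a middle estimate of 1500 nM in this assay and a range from 500 nM to 4500 nM.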

Compound 4, half-maximal inhibitory concentration: 1600 nM
The estimate for compound 4 lay 1.1-fold (0.03 log units) below the measured number; the range from low to high includes it.
By their numbers in this assay, from the lowest: compounds 1, 4 and 2 (each within the scatter of the next).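

Compound 3 has no number in this assay to set against compound 4, so the step between them cannot be read. The compounds shown leave open whether ethyl to propyl changes the result in this assay at all. No supporting data bearing on a cause accompany these values.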